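A few compounds are considered here, and "the series" means these few. Any claim that something is new, unique, unknown or untested is made for them only; others in the source may bear on it.

Measured so far:
compound 1 `CSC(=CC(=O)c1ccc([N+](=O)[O-])cc1)SC`: 40500 nM
compound 2 `CC(C)(C)OC(=O)N1CCN(c2cc(-c3ccc(Oc4ccccc4)cc3)n[nH]2)CC1`: 30000 nM
compound 3 `CCc1ccc(C(=O)CC(=O)C2CCOCC2)cc1`: 202000 nM

All three values come from an ADME assay on L6 cells (Rattus norvegicus) for cytotoxicity; a higher number here means a weaker inhibitor, a lower number a stronger inhibitor. Compound 3 has the highest number of the three, so it is the weakest inhibitor; compound 1 is nearest to it and compound 2 furthest, and both gaps lie beyond the usual scatter. Compound 4 `O=C(CC(=O)C1CCOCC1)c1ccc(Oc2ccccc2)cc1` differs from compound 3 in one place: phenoxy in place of ethyl on an aromatic carbon. Going by the values given here, no two measured compounds differ in a single place, so the size of this step must be judged loosely. Compound 2, which also carries a phenoxy, gives 30000 nM, a clearly lower number. A moderate move toward lower numbers, beyond the scatter, is expected for the step of a 2.2-fold lower number from compound 3 to compound 4 (0.35 log units; beyond the scatter). Compound 4 is estimated at 90000 nM, within 30000 nM to 250000 nM.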

Compound 4, half-maximal inhibitory concentration: 231000 nM
The estimate for compound 4 lay 2.6-fold (0.41 log units) below the measured number; the range from low to high includes it.
By their numbers in this assay, from the lowest: compounds 2 and 1 (each within the scatter of the next); then compounds 3 and 4 (each within the scatter of the next).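

In this assay, replacing ethyl with the much larger phenoxy on this aromatic carbon produces no change that can be told from the scatter (a 1.1-fold higher number from compound 3 to compound 4 (0.06 log units; within the scatter)). At this position, then, adding an aromatic ring and several heavy atoms does not shift the number between these two compounds. Nothing measured here explains this result.

Still open, on these data alone, is whether an amine or a carboxylic acid at this carbon would move the number. It is also unclear whether the same swap would behave alike on a different core.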